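This account rests on a few compounds, and the source may have more. Where it says the series, first, only, none or still open, it means among the compounds named here.

Working notes on the series: in a functional assay on MCF7 cells (Homo sapiens) for antiproliferative activity, read by MTT assay, with a stated time of 72 h (on this read-out higher numbers stand for weaker inhibition and lower numbers for stronger inhibition), compound 1 `O=C1COc2ccc(-c3cnc(Cl)c(NS(=O)(=O)c4ccc(F)cc4)c3)cc2N1C1CCCCC1` gives > 40000 nM, which is a limit of the assay and not a number. Compound 2 `COc1ncc(-c2ccc3c(c2)N(c2ccc(F)cc2)C(=O)CO3)cc1NS(=O)(=O)c1ccc(F)cc1` gives > 40000 nM, likewise only a limit. Both known results therefore stand together: the limit of > 40000 nM in this assay, at which 2 of the 2 values shown sit. Compound 3 `O=C1COc2ccc(-c3cnc(Cl)c(NS(=O)(=O)c4ccc(F)cc4)c3)cc2N1c1ccc(F)cc1` has chloro in place of methoxy on an aromatic carbon, next to the ring nitrogen and ortho to the ((4-fluorophenyl)sulfonyl)amino group: chloro in place of methoxy on an aromatic carbon. No measured step sizes this change, so in this assay nothing beyond the scatter is expected, and the estimated move is a number no higher from compound 2 to compound 3 (the limit leaves the size open). Compound 3 is estimated at 40000 nM, with an expected range from 15000 nM to 80000 nM.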

Compound 3, half-maximal inhibitory concentration: 32600 nM
Compound 3: middle estimate off by 1.2-fold (0.09 log units), on the high side; low and high end bracket the measured number.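

In this assay, going by these compounds alone, compound 3 gives the only value that is a number and not a limit. Chloro in place of methoxy, next to the ring nitrogen, reads as an at least 1.2-fold lower number from compound 2 to compound 3 (0.08 log units; that floor lies within the scatter), and 4-fluorophenyl in place of cyclohexyl on the amide-type nitrogen reads as an at least 1.2-fold lower number from compound 1 to compound 3 (0.08 log units; that floor lies within the scatter). Both steps are floors only, so neither change is shown to act beyond the scatter, and the series stays near the assay's limit: the limit of > 40000 nM in this assay, at which 2 of the 3 values shown sit.

As far as these compounds go, the true distance of compound 1 and compound 2 from compound 3 stays open. Also open, from the compounds shown here alone, is whether an amine or a carboxylic acid in place of chloro would bring the number well down.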